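The source may report more compounds than this note shows. Statements on the series, on what has been measured and on what is new or still open speak of the compounds shown alone.

Of the compounds shown here, two measured so far share one core and differ only in the aryl group on a saturated chain carbon bound to an amine nitrogen. In a functional assay on HPAC cells (Homo sapiens) for inhibition, read by MTT assay, with a stated time of 72 h (on this read-out higher numbers stand for weaker inhibition of growth and lower numbers for stronger inhibition of growth), compound 1 `O=S(=O)(NCCCNCc1ccc(Cl)c(C(F)(F)F)c1)c1cc(C(F)(F)F)cc(C(F)(F)F)c1` gives 3000 nM. In this assay compound 2 `O=S(=O)(NCCCNCc1cccc2ccccc12)c1cc(C(F)(F)F)cc(C(F)(F)F)c1` gives 2400 nM, which stands at the low end of the two measured numbers, though the gap between them, a 1.3-fold lower number from compound 1 to compound 2 (0.10 log units; within the scatter), lies within the scatter and so marks no real difference. Compound 3 `COc1ccccc1CNCCCNS(=O)(=O)c1cc(C(F)(F)F)cc(C(F)(F)F)c1` carries the change (2-methoxyphenyl in place of naphthalen-1-yl on a saturated chain carbon bound to an amine nitrogen). For the measured compounds named here, only one measured step bears on it, a 1.3-fold lower number from compound 1 to compound 2 (0.10 log units; within the scatter), which also exchanged one aryl group for another at the same place and stayed within the scatter. On that evidence no shift beyond the scatter is expected in this assay, and the expected step is a 1.1-fold higher number from compound 2 to compound 3 (0.05 log units; within the scatter). Compound 3 is therefore estimated at 2700 nM, with a likely range from 900 nM to 8000 nM.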

Compound 3, concentration for 50% growth inhibition: 2400 nM
The estimate for compound 3 lay 1.1-fold (0.05 log units) above the measured number, within the range that was stated.
By their numbers in this assay, from the lowest: compounds 2, 3 and 1 (each within the scatter of the next).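

At this place, on a saturated chain carbon bound to an amine nitrogen, one aromatic ring and a hydrogen-bond acceptor can stand in for two aromatic rings and no acceptor: in this assay the exchange gives no change at the digits printed from compound 2 to compound 3 (within the scatter) and so leaves the reading in place. Set against the chlorinated, trifluoromethylated aryl group, 2-methoxyphenyl gives a 1.3-fold lower number from compound 1 to compound 3 (0.10 log units; within the scatter) in the same assay, so all three aryl groups now read alike within the scatter. Nothing available gives a reason for this sameness.

From the compounds shown here alone, all three compounds keep an aromatic ring of carbon only at this place, so it stays open whether a plain methyl group, or a ring carrying a carboxylic acid, would read the same. Also open, going by these compounds, is what a longer chain in the shared core would do.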